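Thiophene-carboxamide series: pyrazolyl amide replacing hydroxy-neopentyl amide

The compounds below may be only part of what the source reports. "The series", "measured", "known", "first", "only" and "open" are said of these compounds alone.

Three compounds have numbers in an assay on cells for positive allosteric modulation of Cystic fibrosis transmembrane conductance regulator variant G551D (Homo sapiens), with stated times of 10 min and 2 min, in the presence of a further agent that is not named here; a higher number here means that more compound is needed for the effect, a lower number that less compound is needed. Compound 1 `CC1(C)Cc2c(sc(NC(=O)c3ccccc3O)c2C(N)=O)CO1` gives 490 nM, and compound 2 `CC1Cc2c(sc(NC(=O)c3ccccc3O)c2C(N)=O)C(C)O1` gives 236 nM; these two lie within the usual scatter of one another, so no order between them is claimed. Compound 3 `CC1(C)Cc2c(sc(NC(=O)[C@H](O)C(C)(C)C)c2C(N)=O)C(C)(C)O1` gives 7780 nM, the highest number of the three, beyond the scatter relative to both compound 1 and compound 2. It is also the only one of the three whose amide carries no ring on the carbonyl carbon; compound 1 and compound 2 both carry a ring there, as their structures show.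

Compound 4 `CC1(C)Cc2c(sc(NC(=O)c3cc(C(F)(F)F)n[nH]3)c2C(N)=O)C(C)(C)O1` is not yet measured. It differs from compound 3 in one place: 3-(trifluoromethyl)-1H-pyrazol-5-yl in place of 1-hydroxy-2,2-dimethylpropyl on a carbonyl carbon. The change thus returns a ring-bearing amide to the carbonyl carbon, the arrangement seen in compound 1 and compound 2. On that basis compound 4 is expected to move the number down from compound 3, a step of an 11-fold lower number from compound 3 to compound 4 (1.05 log units; beyond the scatter) that should exceed the scatter, because compound 1 with a ring on the same carbonyl gives 490 nM. Whether a five-membered ring with two hetero atoms behaves like the rings in compound 1 and compound 2 is not shown by any measured pair, so the range is kept wide. For compound 4 in this assay the estimate is 700 nM, with a range from 150 nM to 3500 nM.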

Compound 4, half-maximal effective concentration: 130 nM
For compound 4 the middle estimate is 5.4-fold (0.73 log units) above the measured one, outside the stated range (below it).
By their numbers in this assay, from the lowest: compounds 4 and 2 (each within the scatter of the next); then compound 1; then compound 3.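

At the carbonyl carbon whose other neighbour is the amide-type nitrogen, this assay records a 60-fold lower number from compound 3 to compound 4 (1.78 log units; beyond the scatter) on replacing 1-hydroxy-2,2-dimethylpropyl with 3-(trifluoromethyl)-1H-pyrazol-5-yl, and the rest of the structure stays unchanged. For the compounds shown here, the earlier compounds differ from one another in more than one place, so this is the first measured step that isolates the group on this carbonyl, and it shows that a five-membered aromatic ring with 2 hetero atoms is tolerated there, with no defined stereocentre in the entering group. No measurement bearing on the size of this step is available, so the result stands as an observation without an assigned cause.

The compounds shown do not separate the contribution of the ring from that of the trifluoromethyl group, which leaves open what a methyl group or a single chlorine atom would give in its place on the same ring. From the compounds shown here alone, it also remains open whether the same exchange gives a step of similar size on the cores of compound 1 and compound 2.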